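Replacing 4-hydroxycyclohexyl with 3-hydroxybenzyl in compound 4

This account rests on a few compounds, and the source may have more. Where it says the series, first, only, none or still open, it means among the compounds named here.

In a functional assay on HL-60 cells (Homo sapiens) for inhibition, read by CCK-8 assay, with a stated time of 48 h (a higher number here means a weaker inhibitor, a lower number a stronger inhibitor), compound 3 (`O=[N+]([O-])c1ccc(NC(=S)NCCNS(=O)(=O)c2ccc(-c3ccccc3O[C@H]3CC[C@@H](O)CC3)s2)cc1`) has no number, only a limit (> 50000 nM). Compound 1 (`O=C(NCCNS(=O)(=O)c1ccc(-c2ccccc2O[C@H]2CC[C@@H](O)CC2)s1)Nc1ccc([N+](=O)[O-])cc1`) likewise gives only a limit (> 20000 nM). Among the measured compounds shown here, the one measured step between compounds that differ in a single place (a step that the two limits leave unreadable from compound 1 to compound 3) therefore offers no size to carry forward.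

Compound 4 (`O=[N+]([O-])c1ccc(NC(=S)NCCNS(=O)(=O)c2ccc(-c3ccccc3OCc3cccc(O)c3)s2)cc1`) differs from compound 3 in one group, with 3-hydroxybenzyl in place of 4-hydroxycyclohexyl on an oxygen on an aromatic ring. For the measured compounds named here, no measured pair isolates this change. The nearest guide is compound 2 (`O=C(NCCNS(=O)(=O)c1ccc(-c2ccccc2OCc2cccc(O)c2)s1)Nc1cc(Cl)cc(Cl)c1`), which carries the same 3-hydroxybenzyl group and gives a real number (2800 nM). Compound 2 also differs from compound 4 outside this group, so it is only a loose guide.

A lower number, meaning stronger inhibition, is still expected for compound 4 because compound 2 gives 2800 nM with this group. The estimated change is an at least 4.1-fold lower number from compound 3 to compound 4 (0.61 log units; beyond the scatter). A limit for compound 4 would leave this change unreadable. Compound 4 is estimated at 12000 nM within an expected range of 3500 nM to 40000 nM in the same read-out.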

Compound 4, half-maximal inhibitory concentration: 10800 nM
Estimate against measurement, compound 4: 1.1-fold (0.05 log units) above; measured number inside the range.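

In this assay, among the compounds shown here, the earlier compounds gave no readable effect for the group on an oxygen on an aromatic ring, but this pair does: 3-hydroxybenzyl in place of 4-hydroxycyclohexyl gives an at least 4.6-fold lower number from compound 3 to compound 4 (0.66 log units; beyond the scatter). That size is only a minimum, because compound 3 has no number, only a limit: the limit of > 50000 nM in this assay, at which 1 of the 4 values shown sits. With 3-hydroxybenzyl held constant, the group on the amine nitrogen also makes a difference, with a 3.9-fold higher number from compound 2 to compound 4 (0.59 log units; beyond the scatter), so this oxygen substituent is not the only part of these compounds that shifts the read-out.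

For the compounds shown here, the steps that rest on two limits cannot be read, including the one from compound 1 to compound 3, so the effect of exchanging the urea for the thiourea remains unknown. The compounds shown also leave open whether the hydroxyl matters in the 3-hydroxybenzyl group, and how a plain benzyl group, or a benzyl group bearing an amine or a carboxylic acid, would behave on the same oxygen.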